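The source may report more compounds than this note shows. Statements on the series, on what has been measured and on what is new or still open speak of the compounds shown alone.

Measured compounds:
- compound 1, `Clc1ccc(C(/C=C/c2ccccc2)=N\Nc2nncc3ccccc23)cc1`, gives 9.6 nM in a functional assay on NCI-H460 cells (Homo sapiens) for antiproliferative activity, read by sulforhodamine B assay, with a stated time of 72 h; a higher number here means a weaker inhibitor, a lower number a stronger inhibitor
- compound 2, `Cc1cc(NS(=O)(=O)c2ccc(Nc3nncc4ccccc34)cc2)no1`, gives 28 nM in this assay

Of the two numbers, compound 2 holds the higher one; the gap to compound 1 lies beyond the scatter. Compound 3, `O=S(=O)(Nc1ccccn1)c1ccc(Nc2nncc3ccccc23)cc1`, is not yet measured in this assay. It differs from compound 2 in one place: pyridin-2-yl in place of 5-methyl-1,2-oxazol-3-yl on a sulfonamide nitrogen. Among the compounds with values here, no step between measured compounds informs this change, so no direction can be read from the data. A step of about no change beyond the scatter is expected, a 1.1-fold higher number from compound 2 to compound 3 (0.03 log units; within the scatter). Compound 3 is estimated at 30 nM, between 10 nM and 90 nM.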

Compound 3, half-maximal inhibitory concentration: 43 nM
Beside the measured number, compound 3's estimate is 1.4-fold (0.16 log units) below it; low and high end bracket the measured number.
By their numbers in this assay, from the lowest: compound 1; then compounds 2 and 3 (each within the scatter of the next).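

On a sulfonamide nitrogen, pyridin-2-yl in place of 5-methyl-1,2-oxazol-3-yl gives a 1.5-fold higher number from compound 2 to compound 3 (0.19 log units; within the scatter) in this assay as the first step read at this position. The position therefore holds either aromatic ring without a change beyond the scatter, although one ring is five-membered with 2 hetero atoms and the other six-membered with 1. No available evidence bears on this result.

Still open, as far as these compounds go, is how a non-aromatic group, such as a methyl or a longer alkyl chain, would read on this nitrogen in this assay.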